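Phenyl-diaminoquinoxaline series: ether and thioether variants in TK-10 cells

This account rests on a few compounds, and the source may have more. Where it says the series, first, only, none or still open, it means among the compounds named here.

Compound 1 `Nc1cc(N)c2nc(-c3ccccc3)c(Oc3ccc(Cl)c(Cl)c3)nc2c1` is the reference for this note. In a functional assay on TK-10 cells (Homo sapiens) for inhibition, read by sulforhodamine B assay, with a stated time of 48 h (a higher number here means a weaker inhibitor of growth, a lower number a stronger inhibitor of growth), compound 1 gives 63100 nM, the higher of the two numbers shown in the set. Compound 3 `CCOC(=O)[C@H](CCC(=O)O)NC(=O)c1ccc(Oc2nc3cc(N)cc(N)c3nc2-c2ccccc2)cc1` carries an ester-bearing side chain on its aryl ether and in this assay compound 3 gives 17800 nM, a lower number than compound 1, and the gap between the two lies beyond the scatter. Compound 2 `CCOC(=O)[C@H](CCC(=O)O)NC(=O)c1ccc(Sc2nc3cc(N)cc(N)c3nc2-c2ccccc2)cc1` is the sulfur counterpart of compound 3 and in this assay compound 2 gives only < 100000 nM, which is a limit of the assay and not a number (the limit of < 100000 nM in this assay, at which 1 of the 3 values shown sits).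

Compound 4 `Nc1cc(N)c2nc(-c3ccccc3)c(Sc3ccc(F)cc3)nc2c1` is not yet measured. It differs from compound 1 in one place: (4-fluorophenyl)sulfanyl in place of 3,4-dichlorophenoxy on an aromatic carbon. For the measured compounds named here, no measured pair in the set isolates this change, so its effect in this assay is unknown. The expected step of a 1.3-fold lower number from compound 1 to compound 4 (0.10 log units; within the scatter) is none beyond the scatter. Compound 4 is therefore estimated at 50000 nM, with a range from 15000 nM to 150000 nM.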

Compound 4, concentration for total growth inhibition: < 100000 nM
Compound 4: no number, only a limit; the forecaster's own chance of this, stated with the estimate: 25%; the middle value does not contradict the limit.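

In this assay compound 4 gives < 100000 nM, a limit of the assay and not a number. For the compounds shown here, no step from compound 1 to compound 4 can therefore be read: the limit of < 100000 nM in this assay, at which 2 of the 4 values shown sit. Still open, on these data alone, is whether (4-fluorophenyl)sulfanyl in place of 3,4-dichlorophenoxy on the shared core changes growth inhibition at all, and in which direction.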